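The compounds below may be only part of what the source reports. "The series", "measured", "known", "first", "only" and "open" are said of these compounds alone.

Compound 1 `O=C(/C=C/c1ccc2c(c1)B(O)OC2)c1ccc(F)cc1` is the anchor of this small set. In a toxicity assay on WI-38 cells (Homo sapiens) for cytotoxicity, read by MTT assay, with a stated time of 48 h (a higher number here means a weaker inhibitor, a lower number a stronger inhibitor), compound 1 gives 7600 nM. Compound 2 `O=C(/C=C/c1ccc2c(c1)B(O)OC2)c1ccc(O)cc1` carries a hydroxy where compound 1 carries a fluoro. In this assay compound 2 gives > 100000 nM, which is a limit of the assay and not a number (the limit of > 100000 nM in this assay, at which 1 of the 2 values shown sits). The one measured step, an at least 13-fold higher number from compound 1 to compound 2 (1.11 log units; beyond the scatter), is therefore open-ended on the weak side, and compound 2 stands at the far end of the numbers shown, with only a limit to mark its place.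

Compound 3 `O=C(/C=C/c1ccc2c(c1)B(O)OC2)c1ccccc1F` has not yet been measured in this assay. It differs from compound 2 by 2-fluorophenyl in place of 4-hydroxyphenyl on a carbonyl carbon: the hydroxy is gone, and a fluorine enters as 2-fluorophenyl. Among the compounds with values here, the only step that bears on this change runs the other way, the hydroxy-for-fluoro step an at least 13-fold higher number from compound 1 to compound 2 (1.11 log units; beyond the scatter), which was large. Reversing that exchange gives reason to expect a move back toward a lower number, though the fluorine of compound 3 sits as 2-fluorophenyl rather than in the arrangement of compound 1, so the size is uncertain. Compound 3 is estimated at 12000 nM with a range from 3000 nM to 60000 nM. The expected step is an at least 8.3-fold lower number from compound 2 to compound 3 (0.92 log units; beyond the scatter).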

Compound 3, half-maximal inhibitory concentration: 23600 nM
Compound 3: middle estimate off by 2.0-fold (0.29 log units), on the low side; low and high end bracket the measured number.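

Moving the fluorine on the ring at the carbonyl carbon is not neutral in this assay: 2-fluorophenyl in place of 4-fluorophenyl gives a 3.1-fold higher number from compound 1 to compound 3 (0.49 log units; beyond the scatter), a modest change that lies beyond the scatter. The earlier pair could show only that exchanging fluoro for hydroxy mattered, whereas this step shows that the arrangement of the fluorine on the ring matters too. As far as these compounds go, the exchange of 4-hydroxyphenyl for 2-fluorophenyl still gives an at least 4.2-fold lower number from compound 2 to compound 3 (0.62 log units; beyond the scatter), so a lower number than that of the hydroxy compound does not depend on the 4-fluorophenyl arrangement alone, and the size of this step stays open-ended. Compound 2 provides a limit and not a number: the limit of > 100000 nM in this assay, at which 1 of the 3 values shown sits.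

From the compounds shown here alone, what remains open is whether the hydroxy group itself or its place on the ring accounts for the weak end of this short series, a question that a 2-hydroxyphenyl group at the same carbonyl carbon would bear on. Also open, going by these compounds, is how 3-fluorophenyl, or a ring carrying an amine or a methoxy group, would read in this assay.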